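The source may hold more compounds than are shown below. What is called first, only, known or untested is meant among the compounds shown, and "the series" means these compounds.

Measured so far in an assay on isolated protein for agonist activity at Bile acid receptor (Homo sapiens), read by FRET, with a stated time of 2 h; on this read-out higher numbers stand for an effect only at larger amounts of compound and lower numbers for an effect already at smaller amounts:
- compound 1 `CC(C)c1onc(-c2c(Cl)cccc2Cl)c1COc1ccc(-c2ccc3c(c2)CCCC3C(=O)O)cc1`, 550 nM
- compound 2 `CC(C)c1onc(-c2c(Cl)cccc2Cl)c1COc1ccc(-c2ccc3sc(C(=O)O)cc3c2)cc1`, 250 nM

Compound 2 stands lowest of the two numbers; the only other point, compound 1, is a step beyond the scatter above it. Compound 3 `CC(C)c1onc(-c2c(Cl)cccc2Cl)c1COc1ccc(-c2ccc3c(c2)CC(C(=O)O)C3)cc1` has not been measured. It differs from compound 2 in one place: 2-carboxy-2,3-dihydro-1H-inden-5-yl in place of 2-carboxy-1-benzothiophen-5-yl on an aromatic carbon. Within the data shown here, no step between measured compounds covers this change, so the direction can only be guessed from the two numbers at hand. With compound 1 giving 550 nM as the nearer point of reference, a step of a 2.0-fold higher number from compound 2 to compound 3 (0.30 log units; within the scatter) upward in this assay is expected, somewhat beyond the scatter. Compound 3 is therefore estimated at 500 nM, within a range of 200 nM to 1300 nM.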

Compound 3, half-maximal effective concentration: 750 nM
Estimate against measurement, compound 3: 1.5-fold (0.18 log units) below, and the stated range covers the measured number.
By their numbers in this assay, from the lowest: compound 2; then compounds 1 and 3 (each within the scatter of the next).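

In this assay, the aromatic carbon para to a large group proves sensitive to the ring carrying the carboxy group: 2-carboxy-2,3-dihydro-1H-inden-5-yl in place of 2-carboxy-1-benzothiophen-5-yl gives a 3.0-fold higher number from compound 2 to compound 3 (0.48 log units; beyond the scatter). This single change therefore separates the two groups beyond the scatter, even though both keep the carboxy group and the six-membered aromatic ring of carbon only. No measurement on hand bears on the origin of this step.

The change removes the sulfur and the aromatic character of the five-membered ring together, and the compounds shown do not tell these two apart; a 2-carboxy-1-benzofuran-5-yl group would bear on that question. Also open, going by these compounds, is how this position responds to a tetrazole in place of the carboxylic acid.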